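The source may hold more compounds than are shown below. What is called first, only, known or untested is meant among the compounds shown, and "the series" means these compounds.

Measured so far:
compound 1 `O=C(CN(c1nc(Cl)nc2[nH]cnc12)C1CC1)N[C@@H](CC(=O)OCc1ccccc1)C(=O)OCc1ccccc1` — 12.1%
compound 2 `O=C(O)CC[C@H](NC(=O)CN(c1nc(Cl)nc2[nH]cnc12)C1CC1)C(=O)O` — 30.1%
compound 3 `O=C(CN(c1ncnc2c1ncn2C1CCCCO1)C1CC1)N[C@@H](CC(=O)OCc1ccccc1)C(=O)OCc1ccccc1` — 7.82%

In a functional assay on the whole organism (Tail, strain ICR) with Mus musculus as the target, in the tail flick test, with a stated time of 120 min, at a dose of 25 umol/kg by the oral route (on this read-out higher numbers stand for a stronger effect at the one dose given and lower numbers for a weaker effect), compound 2 gives 30.1%, the highest of the three numbers. Compound 1 sits lower by a gap beyond the scatter, and compound 3 lower still by a larger gap, also beyond the scatter. Compound 4 `NC(=O)CC[C@H](NC(=O)CN(c1nc(Cl)nc2[nH]cnc12)C1CC1)C(=O)O` is not yet measured. It differs from compound 2 as follows: amino in place of hydroxy on a carbonyl carbon. Among the compounds with values here, no pair of measured compounds shows this change, so its size cannot be read from the series. A small step is expected, most likely downward or none beyond the scatter. For compound 4 the estimate in this assay is 25%, with a range from 12% to 40%. The estimated step is a number 5.1 percentage points lower from compound 2 to compound 4 (within the scatter).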

Compound 4, a percentage reported as activity, at one dose (the size of the read-out at that dose, not a potency): 17.8%
The estimate for compound 4 lay 7.2 percentage points above the measured number; the range from low to high includes it.
By their numbers in this assay, from the lowest: compounds 3, 1 and 4 (each within the scatter of the next); then compound 2.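

In this assay, within the data shown here, carbamoyl in place of carboxy on the 2-carboxyethyl chain gives a number 12.3 percentage points lower from compound 2 to compound 4 (beyond the scatter) and is the first step that changes one place only. The terminal hydroxy on this carbonyl carbon therefore matters to the read-out at this dose, although the swap leaves the counted hydrogen-bond donors and acceptors unchanged. Nothing available explains the step.

Open, on these data alone, is whether a methyl ester or a tetrazole at this chain end would keep the number of compound 2. Also open, as far as these compounds go, is whether a longer chain would do so.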